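The compounds below may be only part of what the source reports. "The series", "measured", "known", "first", "only" and "open" are said of these compounds alone.

Within the data shown here, compound 1 `COc1cc2ncnc(Nc3cccc(Cl)c3)c2cc1OCCCCC(=O)Nc1ccc(S(N)(=O)=O)cc1` carries the only number in a functional assay on A549 cells (Homo sapiens) for antiproliferative activity, read by MTT assay, with a stated time of 72 h; a higher number here means a weaker inhibitor, a lower number a stronger inhibitor: compound 1 gives 11200 nM. Compound 2 `COc1ccc(Nc2ncnc3cc(OC)c(OCCCCC(=O)Nc4ccc(S(N)(=O)=O)cc4)cc23)cc1OC` reaches only a limit of this assay, > 40000 nM. Compound 3 `COc1ccccc1Nc1ncnc2cc(OC)c(OCCCCC(=O)Nc3ccc(S(N)(=O)=O)cc3)cc12` differs from compound 1 in one place: 2-methoxyphenyl in place of 3-chlorophenyl on a nitrogen on an aromatic ring. Among the measured compounds shown here, the single measured step that bears on this change is an at least 3.5-fold higher number from compound 1 to compound 2 (0.55 log units; beyond the scatter), where a methoxy-bearing phenyl likewise replaced the 3-chlorophenyl and the value ran into (the limit of > 40000 nM in this assay, at which 1 of the 2 values shown sits). For compound 3 a weaker inhibitor is therefore expected, with a step of a 2.7-fold higher number from compound 1 to compound 3 (0.43 log units; beyond the scatter). Compound 3 is estimated at 30000 nM, within 12000 nM to 70000 nM.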

Compound 3, half-maximal inhibitory concentration: 24100 nM
The estimate for compound 3 lay 1.2-fold (0.10 log units) above the measured number, within the range that was stated.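

In this assay, a methoxy-bearing phenyl on this nitrogen now gives a true number instead of a limit: a 2.2-fold higher number from compound 1 to compound 3 (0.33 log units; beyond the scatter), so the change from 3-chlorophenyl to 2-methoxyphenyl weakens the compound only modestly. The comparison with 3,4-dimethoxyphenyl reads an at least 1.6-fold lower number from compound 2 to compound 3 (0.22 log units; that floor lies within the scatter), so no order between those two groups can be claimed. Compound 2 remains a limit, not a number: the limit of > 40000 nM in this assay, at which 1 of the 3 values shown sits.

Open, on these data alone, is how a 3-methoxyphenyl or an unsubstituted phenyl on the same nitrogen would compare with the 3-chlorophenyl of compound 1. Also open, as far as these compounds go, is whether a 3-bromophenyl would hold that level.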